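Beyond the phenyl ring of compound 2

The source may report more compounds than this note shows. Statements on the series, on what has been measured and on what is new or still open speak of the compounds shown alone.

Compound 1 `N=C(N/C(=N/O)c1nonc1N)c1ccccc1N`: 16600 nM
Compound 2 `N=C(N/C(=N/O)c1nonc1N)c1ccccc1`: 11500 nM

For the measured compounds named here, in an assay on isolated protein for antagonist activity at cytohesin-3 (Mus musculus), read by surface plasmon resonance, with a stated time of 30 min (on this read-out lower numbers stand for stronger inhibition and higher numbers for weaker inhibition), compound 2 shows the lower of the two numbers, though the one measured step, a 1.4-fold lower number from compound 1 to compound 2 (0.16 log units; within the scatter), lies within the scatter. Compound 3 `N=C(N)NC(=N)N/C(=N/O)c1nonc1N` differs from compound 2 by a group of 4 heavy atoms (1 carbon, 3 nitrogen; no ring) in place of a group of 6 heavy atoms (6 carbon; one six-membered aromatic ring of carbon only), on a carbon with a double bond to nitrogen. That step only altered a substituent on the ring that now leaves, so it does not bear on exchanging the ring itself, and no direction can be drawn from it. Compound 3 is therefore expected near 20000 nM, within 6000 nM to 60000 nM. For compound 3 the expected step is a 1.7-fold higher number from compound 2 to compound 3 (0.24 log units; within the scatter).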

Compound 3, half-maximal inhibitory concentration: 24900 nM
For compound 3 the middle estimate is 1.2-fold (0.10 log units) below the measured one, within the range that was stated.
By their numbers in this assay, from the lowest: compounds 2, 1 and 3 (each within the scatter of the next, the first and the last beyond it).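

In this assay, replacing the phenyl on this carbon with the ring-free group of 4 heavy atoms gives a 2.2-fold higher number from compound 2 to compound 3 (0.34 log units; beyond the scatter) and so moves the number beyond the scatter, though only modestly. The earlier step altered only a substituent on the phenyl ring, whereas this one shows that the ring itself can leave at a modest cost in this read-out. Nothing measured here accounts for the change. The step removes the ring and brings in 3 hydrogen-bond donors together, so the compounds shown cannot separate these two changes. A cyclohexyl ring or a simple methyl on this carbon would remain an open case.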